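The compounds below may be only part of what the source reports. "The series", "measured", "known", "first", "only" and "open" are said of these compounds alone.

Notes on the series.

Compound 2 `COC1=CC(=O)c2c(c(COC(=O)c3ccccc3)c(C)n2C)C1=O` is the reference. In a functional assay on V79-379A cells (Cricetulus griseus) for cytotoxicity, read by MTT assay, in the presence of a further agent that is not named here (on this read-out lower numbers stand for stronger inhibition and higher numbers for weaker inhibition), compound 2 gives 200 nM. Compound 1 `COC1=CC(=O)c2c(c(COC(=O)c3ccc(F)cc3)c(C)n2C)C1=O` differs from compound 2 by fluoro in place of hydrogen on an aromatic carbon and in this assay compound 1 gives 300 nM; the step is a 1.5-fold higher number from compound 2 to compound 1 (0.18 log units; within the scatter). Compound 3 `COC1=CC(=O)c2c(c(COc3ccccc3)c(C)n2C)C1=O` differs from compound 2 by phenyl in place of benzoyl on an oxygen on a saturated carbon; in this assay compound 3 gives 700 nM, and the step is a 3.5-fold higher number from compound 2 to compound 3 (0.54 log units; beyond the scatter). Compound 3 therefore carries the highest number of the three measured compounds, its nearest neighbour being compound 1.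

Compound 4 `COC1=CC(=O)c2c(c(COc3ccc(F)cc3)c(C)n2C)C1=O` is not yet measured. It differs from compound 3 by fluoro in place of hydrogen on an aromatic carbon. The same change occurs twice among the compounds shown: once between measured compounds, where it made the step of a 1.5-fold higher number from compound 2 to compound 1 (0.18 log units; within the scatter), and once from compound 3 to compound 4. The two cores on which the change is made differ by phenyl in place of benzoyl on an oxygen on a saturated carbon; the place of the change reads the same in both cases, so it is taken as the same change.

The measured instance of the change stayed within the scatter, so little movement is expected in the second instance. Compound 4 in this assay is expected at about 900 nM, with a likely range from 450 nM to 1800 nM. The expected step is a 1.3-fold higher number from compound 3 to compound 4 (0.11 log units; within the scatter), set beside a 1.5-fold higher number from compound 2 to compound 1 (0.18 log units; within the scatter); it rests on compound 3 at 700 nM and on that single earlier step, which was made on a core that is not the core of compound 3. Among the measured compounds shown here, with only one precedent, the range is kept wide.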

Compound 4, half-maximal inhibitory concentration: 850 nM
Compound 4: middle estimate off by 1.1-fold (0.02 log units), on the high side, within the range that was stated.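

In this assay, fluoro in place of hydrogen on an aromatic carbon, para to a large group, gives a 1.2-fold higher number from compound 3 to compound 4 (0.08 log units; within the scatter), and it sits with the earlier instance of the same change as follows: the same change on two cores in this assay, a 1.5-fold higher number (0.18 log units; within the scatter) from compound 2 to compound 1 and a 1.2-fold higher number (0.08 log units; within the scatter) from compound 3 to compound 4, 1.2-fold (0.09 log units) apart, within the scatter of two such steps. Among the compounds shown here, on the core of compound 2 and the core of compound 3, the change therefore reads alike, leaving the number within the scatter both times, while the one step beyond the scatter here, a 4.3-fold higher number from compound 2 to compound 4 (0.63 log units; beyond the scatter), comes with 4-fluorophenyl in place of benzoyl on the oxygen and so leaves the fluoro step as the smaller movement. For the compounds shown here, this agreement rests on two pairs, one place and one assay, and two steps that both stay within the scatter show only that the change did little on these two cores, not that it would carry over to a core further removed from these or that any larger effect would transfer.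

On these data alone, whether chloro, methoxy, an amine or a carboxylic acid in the same place would also stay within the scatter remains open. Also open, as far as these compounds go, is whether the fluoro step would read the same with a longer chain in place of the methyl groups on the shared core.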